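Removing the 4-methylphenyl group from compound 3

The source may hold more compounds than are shown below. What is called first, only, known or untested is meant among the compounds shown, and "the series" means these compounds.

Compound 1 `CCN(CC)CN1C(=O)/C(=N/NC(=S)Nc2ccc(OC)cc2)c2ccccc21` gives 3500 nM
Compound 2 `CCN(CC)CN1C(=O)/C(=N/NC(=S)Nc2ccccc2)c2ccccc21` gives 32300 nM
Compound 3 `CCN(CC)CN1C(=O)/C(=N/NC(=S)Nc2ccc(C)cc2)c2ccccc21` gives 3800 nM

In an ADME assay on CRFK cells (Felis catus) for cytotoxicity (on this read-out lower numbers stand for higher toxicity in this test and higher numbers for lower toxicity in this test), compound 3 gives 3800 nM and sits level with compound 1, well under compound 2. The next compound is compound 4 `CCN(CC)CN1C(=O)/C(=N/NC(N)=S)c2ccccc21` which has hydrogen in place of 4-methylphenyl on an amide-type nitrogen so the whole ring goes.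

Within the data shown here, no measured step removes that group outright. The measured steps only alter what the ring carries, so they offer indirect guidance. They show a 9.2-fold higher number from compound 1 to compound 2 (0.97 log units; beyond the scatter) for hydrogen in place of methoxy, and an 8.5-fold lower number from compound 2 to compound 3 (0.93 log units; beyond the scatter) for methyl in place of hydrogen, whereas methyl in place of methoxy gives a 1.1-fold higher number from compound 1 to compound 3 (0.04 log units; within the scatter) and so no real change. Among these three, the ring carrying nothing extra gives the highest number. A rise of modest size is therefore expected, though with a wide margin, since this change is much larger than any measured one.

In this assay the estimated step is a 3.9-fold higher number from compound 3 to compound 4 (0.60 log units; beyond the scatter) as a rough expectation. For compound 4 the estimated value is 15000 nM with an expected range from 3500 nM to 70000 nM as the likely span.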

Compound 4, half-maximal cytotoxic concentration: 73800 nM
The estimate for compound 4 lay 4.9-fold (0.69 log units) below the measured number; measured number outside the range, above it.
By their numbers in this assay, from the lowest: compounds 1 and 3 (each within the scatter of the next); then compound 2; then compound 4.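

In this assay the amide-type nitrogen carries the highest number of the series once it holds no aromatic group at all: losing 4-methylphenyl gives a 19-fold higher number from compound 3 to compound 4 (1.29 log units; beyond the scatter) and losing 4-methoxyphenyl gives a 21-fold higher number from compound 1 to compound 4 (1.32 log units; beyond the scatter), both large steps. Even the ring with nothing extra on it falls short of plain hydrogen, since losing phenyl gives a 2.3-fold higher number from compound 2 to compound 4 (0.36 log units; beyond the scatter), a smaller step but still beyond the scatter. The earlier compounds shown here compared only rings with one another, whereas here all three rings go with higher toxicity in this test than hydrogen, and none of the four compounds goes against this.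

Nothing shown here explains why the ring lowers the number. As far as these compounds go, it also remains open whether a non-aromatic group on that nitrogen, such as a butyl chain or a cyclohexyl ring, would stay close to compound 4 or fall towards the ring-bearing compounds.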